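A few compounds are considered here, and "the series" means these few. Any claim that something is new, unique, unknown or untested is made for them only; others in the source may bear on it.

Compound 1 `Cc1nc2c(Sc3ccc(Cl)cc3)cc(Cl)cn2c1[N+](=O)[O-]`: > 7800 nM, a limit
Compound 2 `O=[N+]([O-])c1cnc2c(Sc3ccc(Cl)cc3)cc(Cl)cn12`: > 7800 nM, a limit

In an ADME assay on HepG2 cells (Homo sapiens) for cytotoxicity, read by MTT assay, with a stated time of 72 h (on this read-out higher numbers stand for lower toxicity in this test and lower numbers for higher toxicity in this test), compound 2 has no exact number, as its > 7800 nM is a limit of the assay. Compound 1 is in the same position, and its > 7800 nM is also a limit. The two compounds share one ceiling: the limit of > 7800 nM in this assay, at which 2 of the 2 values shown sit.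

Compound 3 `O=[N+]([O-])c1c(CSc2ccccc2)nc2c(Sc3ccc(Cl)cc3)cc(Cl)cn12` keeps the core of compound 2 but carries (phenylsulfanyl)methyl in place of hydrogen on an aromatic carbon, next to the ring atom that bears a nitro group: (phenylsulfanyl)methyl in place of hydrogen on an aromatic carbon.

Within the data shown here, only one measured step bears on this change, since it concerns the same carbon. That step, a step that the two limits leave unreadable from compound 1 to compound 2, exchanges methyl for hydrogen, and its size cannot be read, so it offers no size to carry over to the new group. Among the measured compounds shown here, nothing measured so far points either way in this assay, so no shift beyond the usual scatter is expected. The expected step is a step that the limit leaves unreadable from compound 2 to compound 3. For compound 3 the estimated value is 8000 nM, with an expected range from 3000 nM to 25000 nM.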

Compound 3, half-maximal cytotoxic concentration: > 15600 nM
Compound 3 gave a limit, no number (the forecaster's own chance of this, stated with the estimate: 65%); middle value at least 1.9-fold (0.29 log units) from the limit.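

In this assay compound 3 gives > 15600 nM, which is a limit and not a number. Among these compounds, compound 1 and compound 2 also stand at limits, so no step among compound 1, compound 2 and compound 3 can be read. The compounds shown leave open whether methyl or (phenylsulfanyl)methyl in place of hydrogen shifts the value in this assay at all.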